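Triazole in place of cyanopyridyl on the shared core

The source may hold more compounds than are shown below. What is called first, only, known or untested is meant among the compounds shown, and "the series" means these compounds.

Two compounds of the series have numbers in a functional assay on HEK293 cells for agonist activity at Bombesin receptor subtype-3 (Homo sapiens), read by luminescence and calcium flux, with a stated time of 10 min; a higher number here means that more compound is needed for the effect, a lower number that less compound is needed. Compound 1 `CCC(C)(C)Cc1c[nH]c(CCc2ccc(-c3cccc(C#N)n3)cc2)n1` gives 193 nM, the lowest of the two numbers. Compound 2 `c1ccc(-c2ccc(CCc3nc(CC4CCCC4)c[nH]3)cc2)nc1` gives 425 nM, a higher number than compound 1 by a gap beyond the scatter. Among the compounds with values here, compound 2 differs from compound 1 in more than one place, so the two values show only that the pair sits apart.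

Compound 3 `CCC(C)(C)Cc1c[nH]c(CCc2ccc(-n3cncn3)cc2)n1` has not been measured in this assay. Its difference from compound 1 is 1H-1,2,4-triazol-1-yl in place of 6-cyanopyridin-2-yl on an aromatic carbon: on the aromatic carbon para to a large group, a six-membered aromatic ring bearing a nitrile gives way to a five-membered aromatic ring with three hetero atoms, the shared core and the side chain kept. Within the data shown here, no measured pair isolates an exchange of this kind, so nothing anchors the step. A step toward a higher number, of modest size and likely beyond the scatter, is expected for compound 3. Compound 3 is estimated at 450 nM, in a range of 150 nM to 1400 nM. The expected step is a 2.3-fold higher number from compound 1 to compound 3 (0.37 log units; beyond the scatter).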

Compound 3, half-maximal effective concentration: 570 nM
Compound 3: middle estimate off by 1.3-fold (0.10 log units), on the low side; the range from low to high includes it.
By their numbers in this assay, from the lowest: compound 1; then compounds 2 and 3 (each within the scatter of the next).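

In this assay, within the data shown here, 1H-1,2,4-triazol-1-yl in place of 6-cyanopyridin-2-yl on an aromatic carbon para to a large group gives a 3.0-fold higher number from compound 1 to compound 3 (0.47 log units; beyond the scatter), the first step that isolates a single change at this position. The 6-cyanopyridin-2-yl group is therefore not required for a measurable number, as compound 3, with a five-membered aromatic ring bearing three hetero atoms, still gives 570 nM, though the exchange costs a modest step beyond the scatter. Ring size, the hetero atoms and the nitrile all change together in this one exchange, so the step cannot be divided among them, and no measurement at hand accounts for it.

Open, on these data alone, is whether the step follows the nitrile or the ring: a pyridin-2-yl group without the nitrile on this core, a 3-cyanophenyl group, or a pyrazol-1-yl or imidazol-1-yl ring on the same carbon would separate the two. Also open, as far as these compounds go, is how a primary amide or a carboxylic acid in place of the nitrile would read, and whether the same exchange gives a similar step with a side chain other than that of compound 1.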